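From Two Methoxy Groups to Hydroxy and Methoxy

The source may hold more compounds than are shown below. What is called first, only, known or untested is meant among the compounds shown, and "the series" means these compounds.

Measured compounds:
compound 1 `O=C(N/N=C/c1ccc(O)c(O)c1)c1ccc(-c2nc3ccccc3s2)cc1`: 15100 nM
compound 2 `O=C(N/N=C/c1ccc(O)cc1O)c1ccc(-c2nc3ccccc3s2)cc1`: 5580 nM
compound 3 `COc1cc(/C=N/NC(=O)c2ccc(-c3nc4ccccc4s3)cc2)cc(OC)c1`: 16200 nM

These three compounds were tested in an assay on isolated protein for inhibition of Maltase-glucoamylase (Homo sapiens), with a stated time of 15 min; on this read-out higher numbers stand for weaker inhibition and lower numbers for stronger inhibition. Compound 3 gives the highest of the three numbers. Its nearest neighbour is compound 1, and the gap a 1.1-fold higher number from compound 1 to compound 3 (0.03 log units; within the scatter) lies within the scatter, so the two cannot be told apart. Its furthest neighbour is compound 2: the step of a 2.9-fold higher number from compound 2 to compound 3 (0.46 log units; beyond the scatter) is beyond the scatter and modest in size.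

Compound 4 `COc1cc(/C=N/NC(=O)c2ccc(-c3nc4ccccc4s3)cc2)ccc1O` has not yet been measured. It differs from compound 3 in one place: 4-hydroxy-3-methoxyphenyl in place of 3,5-dimethoxyphenyl on a carbon with a double bond to nitrogen. Within the data shown here, two measured steps bear on this change. The step of a 1.1-fold higher number from compound 1 to compound 3 (0.03 log units; within the scatter) shows that exchanging two hydroxy groups for two methoxy groups on that ring brought nothing beyond the scatter, and compound 4 sits between those two patterns, carrying the 4-hydroxy-3-methoxyphenyl group. The step of a 2.9-fold higher number from compound 2 to compound 3 (0.46 log units; beyond the scatter) shows that the one modest gain came with the 2,4-dihydroxyphenyl pattern, which compound 4 does not carry. The expected step of a 1.2-fold lower number from compound 3 to compound 4 (0.10 log units; within the scatter) is therefore small, with no change beyond the scatter. Compound 4 is estimated at 13000 nM, within a range from 5000 nM to 35000 nM.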

Compound 4, half-maximal inhibitory concentration: 53300 nM
For compound 4 the middle estimate is 4.1-fold (0.61 log units) below the measured one; measured number outside the range, above it.
By their numbers in this assay, from the lowest: compound 2; then compounds 1 and 3 (each within the scatter of the next); then compound 4.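

In this assay, among these compounds, the 4-hydroxy-3-methoxyphenyl group is the first on this ring to give a number clearly higher than that of the 3,5-dimethoxyphenyl group (a 3.3-fold higher number from compound 3 to compound 4 (0.52 log units; beyond the scatter)), and it also stands well apart from the 2,4-dihydroxyphenyl group (a 9.6-fold higher number from compound 2 to compound 4 (0.98 log units; beyond the scatter)). The cleanest reading comes from methyl in place of hydrogen on an oxygen on the aromatic ring (a 3.5-fold higher number from compound 1 to compound 4 (0.55 log units; beyond the scatter)): this single change weakens inhibition, yet compound 3, with two methoxy groups, lies within the scatter of compound 1, so among these compounds the number of methoxy groups alone does not set the result, and compound 3 goes against any simple rule that more methoxy means weaker inhibition. The arrangement of groups on this ring therefore matters at this position, but nothing available here accounts for the loss seen with compound 4.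

The compounds shown leave open whether a larger group on that same oxygen, such as ethoxy, would weaken inhibition further. They also leave open whether an amine or a carboxylic acid on this ring would give numbers closer to those of compound 2 or compound 4.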